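Phenyl for pyridin-3-yl on two different rings

The source may hold more compounds than are shown below. What is called first, only, known or untested is meant among the compounds shown, and "the series" means these compounds.

Three compounds were tested in a functional assay on HCT-116 cells (Homo sapiens) for inhibition, read by MTT assay, with a stated time of 24 h, tested at 2.5 uM; a higher number here means more inhibition of growth at the concentration tested, a lower number less inhibition of growth. Compound 1 `CS(=O)(=O)c1ccc(-c2cnc3[nH]cc(-c4nnc(-c5ccccc5)o4)c(=O)c3c2)cc1` gives 0.53%, compound 2 `CS(=O)(=O)c1ccc(-c2cnc3[nH]cc(-c4nnc(-c5cccnc5)o4)c(=O)c3c2)cc1` gives 4.32%, and compound 3 `O=c1c(-c2nnc(-c3ccc(Cl)cc3)o2)c[nH]c2ncc(-c3cccnc3)cc12` gives 10.4%. All three numbers lie within the usual scatter of one another, so no order among them is claimed. Compound 2 and compound 1 differ only by phenyl in place of pyridin-3-yl on an aromatic carbon, and that change made a step of a number 3.8 percentage points lower from compound 2 to compound 1 (within the scatter). Compound 3 carries a different core, and the difference between its core and that of compound 2 is not broken down here.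

Compound 4 `O=c1c(-c2nnc(-c3ccc(Cl)cc3)o2)c[nH]c2ncc(-c3ccccc3)cc12` has not been measured in this assay. It differs from compound 3 by phenyl in place of pyridin-3-yl on an aromatic carbon. This is the same kind of change as from compound 2 to compound 1, but not the same: there the group sat on an aromatic carbon of a five-membered aromatic ring with 2 nitrogen and 1 oxygen, here it sits on an aromatic carbon of a six-membered aromatic ring with 1 nitrogen, part of a fused or bridged system of two rings. Because that earlier step was a number 3.8 percentage points lower from compound 2 to compound 1 (within the scatter), compound 4 is expected to move by about a number 3.4 percentage points lower from compound 3 to compound 4 (within the scatter). Compound 4 is therefore estimated at 7%, with a likely range from 0% to 18%.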

Compound 4, percent growth inhibition at one concentration: 9.81%
For compound 4 the middle estimate is 2.8 percentage points below the measured one, within the range that was stated.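

In this assay, placing phenyl instead of pyridin-3-yl on the aromatic carbon of the six-membered ring gave a step of a number 0.6 percentage points lower from compound 3 to compound 4 (within the scatter). Set beside the earlier case on the five-membered ring, the two steps cannot be told apart: the same change on two cores in this assay, a number 3.8 percentage points lower (within the scatter) from compound 2 to compound 1 and a number 0.6 percentage points lower (within the scatter) from compound 3 to compound 4, 3.2 percentage points apart, within the scatter of two such steps

Within this series, the swap therefore has no effect that can be separated from the scatter at either place, and the earlier step gave no reason to expect otherwise. This does not show that the change carries over with a fixed size, since two pairs at a single concentration cannot reveal an effect smaller than the scatter, nor can they show how the two places would compare if a real effect existed.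

The compounds shown carry only six-membered aromatic rings at these two places, which leaves open how an amine, a carboxylic acid or a longer chain would read there. From the compounds shown here alone, it also remains open whether either pair would separate at another concentration.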